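Cytotoxicity notes: ester in place of pyrrole

The compounds below may be only part of what the source reports. "The series", "measured", "known", "first", "only" and "open" are said of these compounds alone.

In a toxicity assay on NIH3T3 cells (Mus musculus) for cytotoxicity, read by resazurin assay (on this read-out higher numbers stand for an effect only at larger amounts of compound and lower numbers for an effect already at smaller amounts), compound 3 `c1ccc(-c2ccc(Cn3cncc3CNc3ccc(-c4ccc[nH]4)c(-c4ccccc4)c3)cc2)cc1` gives only a limit, > 10000 nM. Compound 1 `c1ccc(-c2ccc(Cn3cncc3CNc3ccc(-c4onc5ccccc45)c(-c4ccccc4)c3)cc2)cc1` likewise reaches only a limit, > 10000 nM. Compound 2 `O=C(c1ccc(NCc2cncn2Cc2ccc(-c3ccccc3)cc2)cc1-c1ccccc1)N1CCCCC1` stops at a limit as well, > 1000 nM. The steps a step that the two limits leave unreadable from compound 1 to compound 2, a step that the two limits leave unreadable from compound 1 to compound 3 and a step that the two limits leave unreadable from compound 2 to compound 3 are therefore all unreadable in size; the limit of > 10000 nM in this assay, at which 2 of the 3 values shown sit, and the limit of > 1000 nM in this assay, at which 1 of the 3 values shown sits, are the only anchors. Compound 4 `O=C(OC1CCCCC1)c1ccc(NCc2cncn2Cc2ccc(-c3ccccc3)cc2)cc1-c1ccccc1` carries the change (cyclohexyloxycarbonyl in place of 1H-pyrrol-2-yl on an aromatic carbon). Among the measured compounds shown here, no measured step bears readably on this change, so neither a direction nor a size beyond the scatter can be read from the three compounds measured. Compound 4 is expected near 15000 nM, within 4000 nM to 60000 nM, most probably again reported as a limit. The expected step is a step that the limit leaves unreadable from compound 3 to compound 4, which no measured number can check.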

Compound 4, half-maximal effective concentration: > 10000 nM
Compound 4 gave a limit, no number; the forecaster's own chance of this, stated with the estimate: 75%; the middle value is on the limit's open side.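

Compound 4 gives only a limit, > 10000 nM. Among the compounds shown here, compound 1, compound 2 and compound 3 also stop at limits, so no step to compound 4 can be read. Left open is at what concentration any of these compounds takes effect, and so how their groups compare.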